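The compounds below may be only part of what the source reports. "The series", "measured", "known", "first", "only" and "open" are said of these compounds alone.

Measured compounds:
- compound 1 `Cc1cn(C2CC(N=[N+]=[N-])C(COC(=O)OCCCC(=O)OC(C)(C)C)O2)c(=O)[nH]c1=O`: 0.267 h
- compound 2 `Cc1cn(C2CC(N=[N+]=[N-])C(COC(=O)NCCCC(=O)O)O2)c(=O)[nH]c1=O`: > 48 h

In an ADME assay on the whole organism (serum) with Homo sapiens as the target (on this read-out higher numbers stand for a longer-lived compound and lower numbers for a shorter-lived compound), compound 1 gives 0.267 h. Compound 2 gives > 48 h, which is a limit of this assay rather than a number; the same limit appears as the limit of > 48 h in this assay, at which 1 of the 2 values shown sits. So compound 2 stands at the upper edge of what the measurement can report, and no step between the two measured compounds is defined, because they differ in more than one place.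

Compound 3 `Cc1cn(C2CC(N=[N+]=[N-])C(COC(=O)OCCCC(=O)O)O2)c(=O)[nH]c1=O` is not yet measured. It differs from compound 2 by 3-carboxypropoxy in place of (3-carboxypropyl)amino on a carbonyl carbon. Among the measured compounds shown here, no measured step of this kind is available to set the size of the change. The expectation is a decrease from compound 2 to compound 3 of an at least 9.6-fold lower number from compound 2 to compound 3 (0.98 log units; beyond the scatter), beyond the scatter. Compound 3 is therefore expected to give about 5 h in this assay, within a range from 0.5 h to 48 h.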

Compound 3, half-life: 13 h
The estimate for compound 3 lay 2.6-fold (0.41 log units) below the measured number, and the stated range covers the measured number.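

In this assay, among the compounds shown here, putting 3-carboxypropoxy in place of (3-carboxypropyl)amino on a carbonyl carbon gives an at least 3.6-fold lower number from compound 2 to compound 3 (0.56 log units; beyond the scatter), the first reading of what this single change does, and it lies beyond the scatter. The value of compound 2 is a limit and not a number, so only a lower bound on that step can be read: the limit of > 48 h in this assay, at which 1 of the 3 values shown sits. For the compounds shown here, compound 3 also gives the first one-place comparison at the other end of the chain, where hydrogen in place of tert-butyl on an oxygen next to a carbonyl group gives a 49-fold higher number from compound 1 to compound 3 (1.69 log units; beyond the scatter), a large step.

As far as these compounds go, the full size of the first step remains open. Also open, from the compounds shown here alone, is how other groups would behave, such as a longer chain on the carbonyl carbon or a methyl group in place of tert-butyl.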